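A few compounds are considered here, and "the series" means these few. Any claim that something is new, unique, unknown or untested is made for them only; others in the source may bear on it.

Measured so far:
compound 1 `COc1ccc(-c2nnc(SCCn3c([N+](=O)[O-])cnc3C)o2)cc1` — in a functional assay on SGC-7901 cells (Homo sapiens) for cytotoxicity, read by MTT assay, with a stated time of 48 h (a higher number here means a weaker inhibitor, a lower number a stronger inhibitor), compound 1 gives 10200 nM
compound 2 `COc1cc(-c2nnc(SCCn3c([N+](=O)[O-])cnc3C)o2)cc(OC)c1OC` — in this assay compound 2 gives 34800 nM

Of these two numbers, compound 1 has the lower one, and its gap to compound 2 lies beyond the usual scatter. Compound 3 `Cc1ncc([N+](=O)[O-])n1CCSc1nnc(-c2cccnc2)o1` has not yet been measured. It differs from compound 1 in one place: pyridin-3-yl in place of 4-methoxyphenyl on an aromatic carbon. Among the compounds with values here, no measured pair shows this kind of change, so the expected step is small and uncertain in direction: compound 3 is estimated to show a step from compound 1 of a 1.5-fold higher number from compound 1 to compound 3 (0.17 log units; within the scatter) in this assay. Compound 3 is therefore expected at about 15000 nM, most likely between 5000 nM and 45000 nM.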

Compound 3, half-maximal inhibitory concentration: 31600 nM
Beside the measured number, compound 3's estimate is 2.1-fold (0.32 log units) below it; the measured number falls inside the stated range.
By their numbers in this assay, from the lowest: compound 1; then compounds 3 and 2 (each within the scatter of the next).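

In this assay, pyridin-3-yl in place of 4-methoxyphenyl gives a 3.1-fold higher number from compound 1 to compound 3 (0.49 log units; beyond the scatter), so this position on the five-membered ring responds to a change of aromatic group, though the step is modest. The swap brings in a ring nitrogen and removes the methoxy group in one move, so the step cannot be assigned to either alone. Nothing measured here accounts for the step. A plain phenyl group would help separate those two changes. On these data alone, how an amine or a carboxylic acid on that aromatic ring would behave also remains open.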